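This account rests on a few compounds, and the source may have more. Where it says the series, first, only, none or still open, it means among the compounds named here.

Working notes on the series. In a functional assay on Huh-7 cells (Homo sapiens) for antiproliferative activity, with a stated time of 48 h (a higher number here means a weaker inhibitor, a lower number a stronger inhibitor), compound 1 `CCN(CC)c1ccc(-c2cccc(OC)c2)nn1` gives > 25000 nM as its read-out, which is a limit of the assay and not a number. Compound 2 `CCN(CC)c1ccc(-c2cccc(C(F)(F)F)c2)nn1` gives > 25000 nM in this assay as well, and this too is only a limit. Among the measured compounds shown here, compound 2 therefore has no numerical position, and the one other value beside it is also a limit. For the measured compounds named here, the single measured step is a step that the two limits leave unreadable from compound 1 to compound 2 and provides no size to carry forward.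

Compound 3 `CCOC(=O)c1cccc(-c2ccc(N(CC)CC)nn2)c1` has ethoxycarbonyl in place of trifluoromethyl on an aromatic carbon, meta to a large group ethoxycarbonyl in place of trifluoromethyl on an aromatic carbon and the shared core is unchanged. No direction can be read from the measured step. Because of the limit of > 25000 nM in this assay, at which 2 of the 2 values shown sit, shared by compound 1 and compound 2, compound 3 is expected to stay near that limit in this assay with no step beyond the scatter. The expected change is a step that the limit leaves unreadable from compound 2 to compound 3 and remains an estimate with little data behind it. The estimated value for compound 3 is 30000 nM with an expected range from 12000 nM to 60000 nM in this assay.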

Compound 3, half-maximal inhibitory concentration: > 25000 nM
Compound 3 was reported as a limit; the forecaster's own chance of this, stated with the estimate: 75%; the middle value does not contradict the limit.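

The steps among compound 1, compound 2 and compound 3 cannot be read, as each read-out in this assay is a limit of the assay and not a number: the limit of > 25000 nM in this assay, at which 3 of the 3 values shown sit.

The compounds shown leave open whether any group at this place on the shared core gives a numerical value in this assay, and how methoxy, trifluoromethyl and ethoxycarbonyl rank.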